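Acetylating the Hydroxymethyl Group of Compound 2

The source may report more compounds than this note shows. Statements on the series, on what has been measured and on what is new or still open speak of the compounds shown alone.

Measured compounds:
compound 1, `CCc1cccc2c(OC)c(-c3occ(C)c3C(=O)On3nnc4ccccc43)ccc12`, > 10 ug/mL
compound 2, `CCc1cccc2c(OC)c(-c3occ(C)c3CO)ccc12`, 7.1 ug/mL

In a functional assay on KB cells (Homo sapiens) for cytotoxicity, read by MTT assay, with a stated time of 72 h (on this read-out lower numbers stand for an effect already at smaller amounts and higher numbers for an effect only at larger amounts of compound), compound 1 gives > 10 ug/mL, which is a limit of the assay rather than a number. For the measured compounds named here, compound 2 gives 7.1 ug/mL in this assay, the only number among the values shown; the other value shown sits at the limit of > 10 ug/mL in this assay, at which 1 of the 2 values shown sits. Compound 3 `CCc1cccc2c(OC)c(-c3occ(C)c3COC(C)=O)ccc12` differs from compound 2 by acetyl in place of hydrogen on an oxygen on a saturated carbon. Going by the values given here, no measured step covers this change, so the expected step of a 1.1-fold higher number from compound 2 to compound 3 (0.05 log units; within the scatter) lies within the usual scatter. Compound 3 is accordingly estimated at 8 ug/mL, between 3 ug/mL and 20 ug/mL.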

Compound 3, concentration for half-maximal effect: > 10 ug/mL
Compound 3 was reported as a limit (the forecaster's own chance of this, stated with the estimate: 40%); at least 1.2-fold (0.09 log units) between middle value and limit.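

In this assay compound 3 gives > 10 ug/mL, which is a limit of the assay and not a number. Hydroxy to acetoxy therefore yields only a floor, an at least 1.4-fold higher number from compound 2 to compound 3 (0.14 log units; that floor lies within the scatter), so the true size of this change remains unknown and it cannot be said whether it exceeds the scatter. Capping this oxygen with acetyl places a second compound at the limit: the limit of > 10 ug/mL in this assay, at which 2 of the 3 values shown sit.

The compounds shown leave open how an amine or a carboxylic acid in place of the hydroxy would read, and equally how a longer acyl chain on this oxygen would read.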